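Fused-ring acrylamides: alkyl amide variation, whole-organism inhibition

This account rests on a few compounds, and the source may have more. Where it says the series, first, only, none or still open, it means among the compounds named here.

Measured so far:
compound 1 `CCN(C)C(=O)/C=C1\CCc2c(F)cc(F)cc21`, 100%;
compound 2 `CN(C)C(=O)/C=C1\CCc2c(F)cc(F)cc21`, 100%;
compound 3 `CCNC(=O)/C=C1\CCc2ccc(F)cc21`, 100%.

All three values come from a functional assay on the whole organism with Mus musculus as the target, at a dose of 100 mg/kg by the intraperitoneal route; a higher number here means more inhibition at the dose given (going by the name of the read-out), a lower number less inhibition. Compound 2 gives 100% and compound 1 gives 100%, so the step of no change at the digits printed from compound 2 to compound 1 (within the scatter) is flat; the change behind it is methyl in place of hydrogen on a saturated chain carbon bound to an amide-type nitrogen. Compound 3, with 100%, stands level with compound 1 and compound 2 at the digits reported. The difference between the core of compound 3 and the core of compound 2 is not broken down here.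

Compound 4 `CC(C)NC(=O)/C=C1\CCc2ccc(F)cc21` is not yet measured in this assay. It differs from compound 3 by methyl in place of hydrogen on a saturated chain carbon bound to an amide-type nitrogen and a saturated chain carbon. Among the compounds with values here, this is the same kind of change as the one from compound 2 to compound 1, but the place is not identical: in the earlier case the carbon is bound to an amide-type nitrogen only, here it is bound to an amide-type nitrogen and a saturated chain carbon.

The expectation for compound 4 rests on the flat step no change at the digits printed from compound 2 to compound 1 (within the scatter) and on the read-out of compound 3 at 100%, which already sits at the top of the scale. The step of no change at the digits printed from compound 3 to compound 4 (within the scatter) is therefore expected to be about nil. Compound 4 is estimated at 100%, with a range from 85% to 100%.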

Compound 4, a percentage reported as inhibition, in the whole organism at one dose (the size of the read-out at that dose, not a potency): 100%
Beside the measured number, compound 4's estimate shows no gap at the digits printed; the measured number falls inside the stated range.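

In this assay, methyl in place of hydrogen on the saturated chain carbon gives no change at the digits printed from compound 3 to compound 4 (within the scatter), and the same kind of change reads alike on the two cores: the same change on two cores in this assay, no change at the digits printed (within the scatter) from compound 2 to compound 1 and no change at the digits printed (within the scatter) from compound 3 to compound 4, 0 percentage points apart, within the scatter of two such steps Within these two pairs, the change carries from the core of compound 2 to the core of compound 3 with no visible shift in the read-out, even though the place differs slightly: on the second core the carbon is bound to an amide-type nitrogen and a saturated chain carbon. This does not show that the change is neutral in general, since compound 4 stands at 100% and all four compounds sit at the top of the scale at a single dose, where a gain cannot appear and a difference in potency would stay hidden.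

The compounds shown leave open whether a longer chain such as butyl, a cyclopropyl group or a carboxylic acid on the amide nitrogen would bring the read-out down from the top of the scale. Also open is what the difference between the two cores contributes, as no pair shown differs in that place alone.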